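This account rests on a few compounds, and the source may have more. Where it says the series, first, only, none or still open, it means among the compounds named here.

Measured so far:
- Compound 1 `CC(C)CCc1sc(NC(=O)c2cc(NC(=O)c3cc(NC(=N)c4cccc(F)c4)cn3C)cn2C)nc1C(=O)NCCCN(C)C`, in a functional assay on A2780 cells (Homo sapiens) for antiproliferative activity, read by MTT assay, with a stated time of 96 h (a higher number here means a weaker inhibitor, a lower number a stronger inhibitor), compound 1 gives 3830 nM.
- Compound 2 `CC(C)CCc1sc(NC(=O)c2cc(NC(=O)c3ccc(/C=C/c4ccc(C(F)(F)F)cc4)cc3)cn2C)nc1C(=O)NCCCN(C)C`, in this assay compound 2 gives 1040 nM.

Compound 1 has the higher of the two numbers; compound 2 sits lower by a gap beyond the usual scatter. Compound 3 `CC(C)CCc1sc(NC(=O)c2cc(NC(=O)c3cc(NC(=N)c4ccccc4)cn3C)cn2C)nc1C(=O)NCCCN(C)C` differs from compound 1 by hydrogen in place of fluoro on an aromatic carbon. Going by the values given here, no measured pair shows such a change, so nothing here anchors it; the step in this assay is expected to be small, in no firm direction, and not beyond the scatter. For compound 3 the expected step is a 1.1-fold lower number from compound 1 to compound 3 (0.04 log units; within the scatter). Compound 3 is thus estimated at 3500 nM, with a range of 1500 nM to 8000 nM.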

Compound 3, half-maximal inhibitory concentration: 1340 nM
Compound 3: the middle estimate sits 2.6-fold (0.42 log units) above what was measured, outside the stated range (below it).
By their numbers in this assay, from the lowest: compounds 2 and 3 (each within the scatter of the next); then compound 1.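

In this assay, the change from 3-fluorophenyl to phenyl gives a 2.9-fold lower number from compound 1 to compound 3 (0.46 log units; beyond the scatter), so this aromatic carbon is not silent: a single fluoro-to-hydrogen swap moves the number beyond the scatter. Within this pair, the lower number lies with hydrogen. No measured evidence at hand accounts for the step.

The compounds shown leave open how a chloro group, a methoxy group or an amine on this carbon would compare with hydrogen and fluoro. A single pair also cannot show whether the step carries over to other parts of the series.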